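This account rests on a few compounds, and the source may have more. Where it says the series, first, only, none or still open, it means among the compounds named here.

Measured so far in an ADME assay on PANC-1 cells (Homo sapiens) for cytotoxicity, read by sulforhodamine B assay, with a stated time of 48 h, tested at 10 uM; on this read-out lower numbers stand for less inhibition and higher numbers for more inhibition at the one concentration tested (going by the name of the read-out):
Compound 1 `COc1nc2ccc(Br)cc2cc1C(c1ccccc1)n1cc(-c2ccccc2F)nn1` gives 14.7%.
Compound 2 `CCCc1cn(C(c2ccccc2)c2cc3cc(Br)ccc3nc2OC)nn1` gives 11.3%.
Compound 3 `COc1nc2ccc(Br)cc2cc1C(c1ccccc1)n1cc(-c2ccc(OC(F)(F)F)cc2)nn1` gives 11.7%.

All three numbers sit together. The step of a number 3 percentage points lower from compound 1 to compound 3 (within the scatter) and the step of a number 0.4 percentage points higher from compound 2 to compound 3 (within the scatter) are both within the scatter, so compound 3 cannot be told apart from either of the other two in this assay.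

Compound 4 `COc1nc2ccc(Br)cc2cc1C(c1ccccc1)n1cc(CCO)nn1` is the next member of the series. It differs from compound 3 in one place: 2-hydroxyethyl in place of 4-(trifluoromethoxy)phenyl on an aromatic carbon.

The measured steps that bear on this change are those at the same aromatic carbon of the shared core: a number 3.4 percentage points lower from compound 1 to compound 2 (within the scatter), a number 3 percentage points lower from compound 1 to compound 3 (within the scatter) and a number 0.4 percentage points higher from compound 2 to compound 3 (within the scatter). None of them is beyond the scatter. Three quite different groups at that carbon have left the read-out in this assay flat, so no step beyond the scatter is expected here either, in either direction, although the 2-hydroxyethyl group has no measured precedent in the series and the range is kept wide for that reason.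

Compound 4 is expected to give 12%, between 3% and 21%. The expected step of a number 0.3 percentage points higher from compound 3 to compound 4 (within the scatter) is therefore within the scatter.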

Compound 4, a percentage reported as inhibition, at one concentration (the size of the read-out at that concentration, not a potency): 19.8%
The estimate for compound 4 lay 7.8 percentage points below the measured number, within the range that was stated.
By their numbers in this assay, from the lowest: compounds 2, 3, 1 and 4 (each within the scatter of the next).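

With the 2-hydroxyethyl group, this aromatic carbon now carries a group with a hydrogen-bond donor and no ring, and this assay still gives no step beyond the scatter: a number 8.1 percentage points higher from compound 3 to compound 4 (within the scatter), a number 8.5 percentage points higher from compound 2 to compound 4 (within the scatter) and a number 5.1 percentage points higher from compound 1 to compound 4 (within the scatter). The second of these is the change of methyl to hydroxy on the saturated chain, and even that single-atom exchange does not separate the two compounds, so all four groups shown at this carbon remain indistinguishable in this assay. Nothing measured here bears on why the read-out stays flat at this position.

Still open, from the compounds shown here alone, is whether an amine or a carboxylic acid in place of the hydroxy, or a longer chain ending in hydroxy, would give a step beyond the scatter. With a single tested concentration, this assay also leaves the potency of all four compounds unresolved.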